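Removing one methyl from compound 2: working notes

This account rests on a few compounds, and the source may have more. Where it says the series, first, only, none or still open, it means among the compounds named here.

Values in a functional assay on HeLa cells (Homo sapiens) for antiproliferative activity, read by MTT assay, with a stated time of 48 h; on this read-out lower numbers stand for stronger inhibition and higher numbers for weaker inhibition:
- compound 1 `Cc1ccc(-c2nn(-c3ccccc3)cc2C(Nc2nc3cc(C)c(C)cc3s2)c2c(O)ccc3ccccc23)cc1`: 17800 nM
- compound 2 `Cc1cc2nc(NC(c3cn(-c4ccccc4)nc3-c3ccc([N+](=O)[O-])cc3)c3c(O)ccc4ccccc34)sc2cc1C`: 14700 nM
- compound 3 `Oc1ccc2ccccc2c1C(Nc1nc2ccc(Cl)cc2s1)c1cn(-c2ccccc2)nc1-c1ccccc1`: 12500 nM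

Compound 4 `Cc1ccc2nc(NC(c3cn(-c4ccccc4)nc3-c3ccc([N+](=O)[O-])cc3)c3c(O)ccc4ccccc34)sc2c1` has not yet been measured.

Compound 2, at 14700 nM, lies within the scatter of both compound 1 and compound 3. Compound 4 differs from compound 2 by hydrogen in place of methyl on an aromatic carbon, which turns 5,6-dimethyl-1,3-benzothiazol-2-yl into 6-methyl-1,3-benzothiazol-2-yl. Going by the values given here, no measured step covers this change. Among the compounds with values here, the only measured step, a 1.2-fold lower number from compound 1 to compound 2 (0.08 log units; within the scatter), is a different change, nitro in place of methyl on an aromatic carbon, and it stays within the scatter. On that slender evidence, no shift beyond the scatter is expected in this assay. The estimated step is a 1.1-fold lower number from compound 2 to compound 4 (0.02 log units; within the scatter). Compound 4 is estimated at 14000 nM, with an expected range of 7000 nM to 28000 nM.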

Compound 4, half-maximal inhibitory concentration: 7040 nM
Compound 4: the middle estimate sits 2.0-fold (0.30 log units) above what was measured; measured number inside the range.
By their numbers in this assay, from the lowest: compounds 4, 3, 2 and 1 (each within the scatter of the next, the first and the last beyond it).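

In this assay, hydrogen in place of methyl on this aromatic carbon, ortho to the remaining methyl, gives a 2.1-fold lower number from compound 2 to compound 4 (0.32 log units; beyond the scatter), a modest change and the only step shown that goes beyond the scatter. This position therefore responds to the loss of a single methyl, whereas nitro in place of methyl in the other step shown, a 1.2-fold lower number from compound 1 to compound 2 (0.08 log units; within the scatter), stays within it. Nothing available explains the shift. The compounds shown do not tell whether losing the remaining methyl would extend the step. They also leave open how an ethyl, an amine or a carboxylic acid on this carbon would read.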